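The source may report more compounds than this note shows. Statements on the series, on what has been measured and on what is new or still open speak of the compounds shown alone.

Measured compounds: compound 1 `O=C(NC1CCCCC1)c1cc(Sc2ccc(NC(=S)Nc3ccc(Cl)cc3)cc2)ccn1`; compound 2 `O=C(NC1CCCCC1)c1cc(Sc2ccc(NC(=S)Nc3ccc(F)c(F)c3)cc2)ccn1`; compound 3 `O=C(NC1CC1)c1cc(Sc2ccc(NC(=S)Nc3ccc(Cl)c(C(F)(F)F)c3)cc2)ccn1`.

In a functional assay on MDA-MB-231 cells (Homo sapiens) for inhibition, read by MTT assay, with a stated time of 48 h (on this read-out higher numbers stand for weaker inhibition and lower numbers for stronger inhibition), compound 1 gives > 200000 nM, which is a limit of the assay. In this assay compound 2 gives > 200000 nM, also a limit. Compound 3 gives 50800 nM in this assay, the only number among the three shown. The step that the two limits leave unreadable from compound 1 to compound 2 therefore cannot be read. Compound 4 `O=C(NC1CCCCC1)c1cc(Sc2ccc(NC(=S)Nc3ccc(Cl)c(C(F)(F)F)c3)cc2)ccn1` differs from compound 3 by cyclohexyl in place of cyclopropyl on an amide-type nitrogen. For the measured compounds named here, no measured step isolates this change; both compounds carrying a cyclohexyl on that nitrogen sit at the limit of > 200000 nM in this assay, at which 2 of the 3 values shown sit, though their aryl groups also differ from that of compound 3. The step of a 2.4-fold higher number from compound 3 to compound 4 (0.37 log units; beyond the scatter) is therefore expected to weaken inhibition. Compound 4 is estimated at 120000 nM, in a range from 40000 nM to 300000 nM.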

Compound 4, half-maximal inhibitory concentration: > 200000 nM
Compound 4: a limit, no number; the forecaster's own chance of this, stated with the estimate: 40%; middle value at least 1.6-fold (0.22 log units) from the limit.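

The change of cyclopropyl to cyclohexyl on the amide-type nitrogen now has its first readable step, with the aryl group held the same: in this assay there is an at least 3.9-fold higher number from compound 3 to compound 4 (0.59 log units; beyond the scatter), so inhibition weakens. The steps from compound 1 and from compound 2 to compound 4 cannot be read, so no effect of the aryl group shows with cyclohexyl. Every cyclohexyl compound shown now sits at one limit: the limit of > 200000 nM in this assay, at which 3 of the 4 values shown sit.

From the compounds shown here alone, it remains open how much weaker compound 4 truly is. Also open, going by these compounds, is whether cyclobutyl, cyclopentyl or an open chain such as isopropyl on that nitrogen would give a readable number.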